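From compound 1 to compound 4: a side-group exchange

A few compounds are considered here, and "the series" means these few. Any claim that something is new, unique, unknown or untested is made for them only; others in the source may bear on it.

Going by the values given here, in a functional assay on SNB-19 cells (Homo sapiens) for inhibition, read by MTT assay, with a stated time of 7 days (on this read-out higher numbers stand for weaker inhibition of growth and lower numbers for stronger inhibition of growth), compound 1 `C[Si](C)(C)CCOCn1nnc2c(C(N)=O)ncn2c1=O` gives 29900 nM, the only true number in this small set. Compound 2 `COc1ccc(Cn2nnc3c(C(N)=O)ncn3c2=O)cc1OC` reports > 50000 nM, which is a limit of the assay and not a number. Compound 3 `COc1cc(Cn2nnc3c(C(N)=O)ncn3c2=O)cc(OC)c1OC` reports > 50000 nM, which is also a limit. Among the compounds with values here, compound 1 is therefore the only measured compound with a readable value.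

Compound 4 `NC(=O)c1ncn2c(=O)n(Cc3c[nH]nn3)nnc12` keeps the core of compound 1 and differs on a saturated chain carbon bound to an aromatic nitrogen: a group of 5 heavy atoms (2 carbon, 3 nitrogen; one five-membered aromatic ring with 3 hetero atoms) in place of a group of 7 heavy atoms (5 carbon, 1 oxygen, 1 silicon; no ring), on a saturated chain carbon bound to an aromatic nitrogen. Within the data shown here, the only measured step between close relatives is a step that the two limits leave unreadable from compound 2 to compound 3, so it gives no size to carry over. The better guide is the limit of > 50000 nM in this assay, at which 2 of the 3 values shown sit. The two compounds concerned, compound 2 and compound 3, hold an aromatic ring on that chain carbon, as compound 4 will, whereas compound 1 holds no ring. A modest move towards weaker inhibition of growth is therefore expected in this assay, starting from compound 1 at 29900 nM. The expected step is a 1.5-fold higher number from compound 1 to compound 4 (0.18 log units; within the scatter). Compound 4 is estimated at 45000 nM, with an expected range of 18000 nM to 110000 nM.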

Compound 4, concentration for 50% growth inhibition: > 50000 nM
Compound 4 was reported as a limit; the forecaster's own chance of this, stated with the estimate: 55%; at least 1.1-fold (0.04 log units) between middle value and limit.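

In this assay, placing 1H-1,2,3-triazol-4-yl on the saturated chain carbon bound to an aromatic nitrogen, in place of the ringless group of compound 1, gives an at least 1.6-fold higher number from compound 1 to compound 4 (0.22 log units; that floor lies within the scatter). Compound 4 gives a limit and not a number, so this step is only a floor, and that floor alone does not establish a real loss of growth inhibition. What the new result adds is that a five-membered aromatic ring with hetero atoms and a hydrogen-bond donor, very different from the methoxy-bearing rings of compound 2 and compound 3, ends at the same limit, so all the ring-bearing compounds shown now sit together there: the limit of > 50000 nM in this assay, at which 3 of the 4 values shown sit.

Going by these compounds alone, compound 1 remains the only compound with a readable value, and the steps among compound 2, compound 3 and compound 4 cannot be read. Still open, as far as these compounds go, is whether a plain longer alkyl chain, an amine or a carboxylic acid at this position would give a number, and whether any group here could move the value clearly below that of compound 1.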